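The source may hold more compounds than are shown below. What is called first, only, known or untested is meant among the compounds shown, and "the series" means these compounds.

Measured so far in an assay on microsomes from liver for inhibition of sterol O-acyltransferase 1 (Rattus norvegicus); a higher number here means a weaker inhibitor, a lower number a stronger inhibitor:
compound 1 `C[C@@]1(O)CC(=O)OC(CSc2nc(-c3ccccc3)c(-c3ccccc3)[nH]2)C1` gives 170 nM
compound 2 `O=C1CC(O)CC(CSc2nc(-c3ccccc3)c(-c3ccccc3)[nH]2)O1` gives 910 nM
compound 3 `c1ccc(-c2nc(SCC3OCCCO3)[nH]c2-c2ccccc2)cc1` gives 180 nM

Compound 3 stands second highest of the three numbers in this assay. Two steps frame it: a 1.1-fold higher number from compound 1 to compound 3 (0.02 log units; within the scatter), within the scatter, whereas a 5.1-fold lower number from compound 2 to compound 3 (0.70 log units; beyond the scatter), beyond it.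

Compound 4 `c1ccc(CSc2nc(-c3ccccc3)c(-c3ccccc3)[nH]2)cc1` differs from compound 3 by a group of 6 heavy atoms (6 carbon; one six-membered aromatic ring of carbon only) in place of a group of 6 heavy atoms (4 carbon, 2 oxygen; one six-membered non-aromatic ring with 2 hetero atoms), on a saturated chain carbon bound to a sulfur. All three measured steps exchange the ring on that same carbon: a 5.4-fold higher number from compound 1 to compound 2 (0.73 log units; beyond the scatter) and a 5.1-fold lower number from compound 2 to compound 3 (0.70 log units; beyond the scatter) were modest, and a 1.1-fold higher number from compound 1 to compound 3 (0.02 log units; within the scatter) was within the scatter. Within the data shown here, a ring swap at this position has so far moved the number by a modest amount at most; no measured step puts a phenyl there, so the direction is open. The expected step is a 1.2-fold lower number from compound 3 to compound 4 (0.08 log units; within the scatter), nothing beyond the scatter. Compound 4 is estimated at 150 nM, with a range of 50 nM to 500 nM.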

Compound 4, half-maximal inhibitory concentration: 290 nM
Estimate against measurement, compound 4: 1.9-fold (0.29 log units) below; the measured number falls inside the stated range.
By their numbers in this assay, from the lowest: compounds 1, 3 and 4 (each within the scatter of the next); then compound 2.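

In this assay the phenyl group on the saturated chain carbon bound to a sulfur holds up with no ring oxygen and no hydrogen-bond acceptors in the group: a 1.6-fold higher number from compound 3 to compound 4 (0.21 log units; within the scatter) and a 1.7-fold higher number from compound 1 to compound 4 (0.23 log units; within the scatter) both lie within the scatter. Only a 3.1-fold lower number from compound 2 to compound 4 (0.50 log units; beyond the scatter) goes beyond it, and modestly, so compound 2 remains the one apart. No supporting evidence bears on this result.

On these data alone, whether an open group such as a longer chain, an amine or a carboxylic acid on that carbon stays in this range remains open. So does the effect of a fluorine or methoxy group on the phenyl ring.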